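A Trimethylbenzyl Swap on a Fluorinated Compound

A few compounds are considered here, and "the series" means these few. Any claim that something is new, unique, unknown or untested is made for them only; others in the source may bear on it.

For the measured compounds named here, compound 1 `COc1ccc2cc([C@H](C)c3nnc(SCc4c(C)cc(C)cc4C)n3-c3cccc(Cl)c3)ccc2c1` gives 16300 nM in a functional assay on PC-3 cells (Homo sapiens) for cytotoxicity, read by MTT assay (on this read-out higher numbers stand for weaker inhibition and lower numbers for stronger inhibition), and supplies the only exact number so far. Compound 2 `COc1ccc2cc([C@H](C)c3nnc(SCc4ccc(F)cc4)n3-c3ccc(F)cc3)ccc2c1` gives <= 400000 nM in this assay as a limit of the assay and not as a number. Compound 2 therefore has no exact place on the scale.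

Compound 3 `COc1ccc2cc([C@H](C)c3nnc(SCc4c(C)cc(C)cc4C)n3-c3ccc(F)cc3)ccc2c1` differs from compound 2 by having 2,4,6-trimethylphenyl in place of 4-fluorophenyl on a saturated chain carbon bound to a sulfur. Compound 1 also carries the 2,4,6-trimethylphenyl group, and its 16300 nM is the main guide here. Going by the values given here, no measured step is available, so a sizeable step towards stronger inhibition is expected, estimated as a step that the limit leaves unreadable from compound 2 to compound 3 and necessarily rough. In this assay compound 3 is expected to give 20000 nM within an estimated range of 6000 nM to 60000 nM at this stage.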

Compound 3, half-maximal inhibitory concentration: 43300 nM
Compound 3: the middle estimate sits 2.2-fold (0.34 log units) below what was measured; low and high end bracket the measured number.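

With the 2,4,6-trimethylbenzyl group held constant, the group on the aromatic nitrogen can now be compared directly. In this assay, 4-fluorophenyl in place of 3-chlorophenyl gives a 2.7-fold higher number from compound 1 to compound 3 (0.42 log units; beyond the scatter), so even this modest change in the aromatic group on that nitrogen moves the result beyond the usual scatter. Compound 2 has a limit of the assay and not a number, so the step at the saturated chain carbon bound to a sulfur cannot be read: the limit of <= 400000 nM in this assay, at which 1 of the 3 values shown sits.

Going by these compounds, the effect of swapping 4-fluorophenyl for 2,4,6-trimethylphenyl at that carbon therefore remains unknown in size and direction. Also open, on these data alone, is how the result would respond to an amine or a carboxylic acid on the aromatic group on the nitrogen, or to a longer chain in place of the 2,4,6-trimethylbenzyl group.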